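Aryl change on the sulfonyl of compound 2

The source may report more compounds than this note shows. Statements on the series, on what has been measured and on what is new or still open speak of the compounds shown alone.

Measured so far in an assay on HEK293 cells for displacement of a labelled ligand from Type-2 angiotensin II receptor (Homo sapiens), tested at 10 uM; on this read-out higher numbers stand for a stronger effect at the one concentration tested and lower numbers for a weaker effect:
compound 1, `CC[C@H](C)[C@H](NC(=O)c1cccc(Cn2ccnc2)c1)C(=O)NS(=O)(=O)c1ccccc1`: compound 1 gives 24%
compound 2, `CC[C@H](C)[C@H](NC(=O)c1cccc(Cn2ccnc2)c1)C(=O)NNS(=O)(=O)c1c(C)cc(C)cc1C`: compound 2 gives 27%
compound 3, `CC[C@H](C)[C@H](NC(=O)c1cccc(Cn2ccnc2)c1)C(=O)Nc1nccs1`: compound 3 gives 17%

The three numbers all lie within the scatter of one another, so none separates from the rest; compound 2 is taken as the reference for the next step. For the measured compounds named here, the only step between two measured compounds that differ in one place is a number 7 percentage points lower from compound 1 to compound 3 (within the scatter), which changes the group on the amide-type nitrogen. It shows that replacing the whole group at that end of the shared core leaves the read-out where it was. Going by the values given here, no measured pair changes the aryl on the sulfonyl sulfur itself.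

Compound 4, `CC[C@H](C)[C@H](NC(=O)c1cccc(Cn2ccnc2)c1)C(=O)NNS(=O)(=O)c1ccc(OC)cc1`, carries 4-methoxyphenyl in place of 2,4,6-trimethylphenyl on a sulfonyl sulfur. Among the compounds with values here, with the one relevant step flat and no direct precedent, the step of a number 2 percentage points lower from compound 2 to compound 4 (within the scatter) is expected to stay within the scatter. For compound 4 in this assay the estimate is 25%, with a range of 12% to 38%.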

Compound 4, a percentage reported as inhibition, at one concentration (the size of the read-out at that concentration, not a potency): 20%
For compound 4 the middle estimate is 5 percentage points above the measured one, and the stated range covers the measured number.
By their numbers in this assay, from the lowest: compounds 3, 4, 1 and 2 (each within the scatter of the next).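

On the sulfonyl sulfur, in this assay, 4-methoxyphenyl in place of 2,4,6-trimethylphenyl gives a number 7 percentage points lower from compound 2 to compound 4 (within the scatter). For the compounds shown here, this is the first direct reading on the aryl at this position; the earlier step concerned the whole group on the amide-type nitrogen. The read-out does not separate these two aryl groups, although the entering group has 1 hydrogen-bond acceptor and the leaving group has 0.

This single pair cannot show how much the methoxy group and the loss of the methyl groups each contribute. It also leaves open whether any group on the sulfonyl sulfur moves the read-out beyond the scatter, for example a phenyl ring carrying a carboxylic acid or an amine, or a cyclohexyl group. No available evidence bears on the reason for this result.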